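Removing the second fluoro from the difluorophenyl amide

The source may report more compounds than this note shows. Statements on the series, on what has been measured and on what is new or still open speak of the compounds shown alone.

Compound 1 `O=C(Nc1cc(-c2ccccc2)nn1-c1ccccc1)c1ccc(F)c(F)c1` stands lowest of the three numbers in an assay on CHO cells with metabotropic glutamate receptor 5 (Homo sapiens) as the target (on this read-out lower numbers stand for an effect already at smaller amounts and higher numbers for an effect only at larger amounts of compound), where compound 1 gives 10 nM. Compound 2 `O=C(Nc1cc(-c2ccccc2)nn1-c1ccccc1)c1ccc(F)cc1` gives 30 nM in this assay; compound 3 `O=C(Nc1cc(-c2ccccc2)nn1-c1ccccc1)c1cccc(Cl)c1` gives 40 nM. Among the compounds with values here, the step of a 3.0-fold higher number from compound 1 to compound 2 (0.48 log units; beyond the scatter) is the closest precedent for removal of a fluoro group; a 4.0-fold higher number from compound 1 to compound 3 (0.60 log units; beyond the scatter) is a comparable size, while a 1.3-fold higher number from compound 2 to compound 3 (0.12 log units; within the scatter) separates the two monosubstituted amides by little. Compound 4 `O=C(Nc1cc(-c2ccccc2)nn1-c1ccccc1)c1cccc(F)c1` differs from compound 1 by hydrogen in place of fluoro on an aromatic carbon. On the precedent of the step from compound 1 to compound 2, a modest loss is expected for compound 4, about a 3.0-fold higher number from compound 1 to compound 4 (0.48 log units; beyond the scatter). In this assay compound 4 is therefore estimated at 30 nM, within 12 nM to 75 nM.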

Compound 4, half-maximal effective concentration: 20 nM
Estimate against measurement, compound 4: 1.5-fold (0.18 log units) above; measured number inside the range.
By their numbers in this assay, from the lowest: compounds 1, 4, 2 and 3 (each within the scatter of the next, the first and the last beyond it).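

In this assay, going from 3,4-difluorophenyl to 3-fluorophenyl gives a 2.0-fold higher number from compound 1 to compound 4 (0.30 log units; within the scatter), so losing the fluoro para to a large group stays within the scatter, whereas the loss of the other fluoro in compound 2 lies beyond it. That contrast is weak, since a 1.5-fold lower number from compound 2 to compound 4 (0.18 log units; within the scatter) does not separate the two monofluoro amides, and a 2.0-fold lower number from compound 3 to compound 4 (0.30 log units; within the scatter) leaves chloro and fluoro at this place equally unresolved. Nothing available speaks to the reason for these numbers.

Still open, from the compounds shown here alone, is whether a methoxy, an amine or a nitrile at this aromatic carbon would keep the number near that of compound 1.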